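The source may report more compounds than this note shows. Statements on the series, on what has been measured and on what is new or still open speak of the compounds shown alone.

In a toxicity assay on MDCK cells (Canis lupus familiaris) for cytotoxicity, read by crystal violet staining, with a stated time of 48 h (a higher number here means that more compound is tolerated, a lower number that less compound is tolerated), compound 3 `CC(C)(C)c1ccc(CN(Cc2ccc(C(F)(F)F)c(Cl)c2)Cc2cc3cc(C4CC4)ccc3[nH]c2=O)cc1` reaches only a limit, > 10000 nM. Compound 2 `CC(c1ccc(N(C)C)c(Cl)c1)N(Cc1ccc(C(C)(C)C)cc1)Cc1cc2cc(C3CC3)ccc2[nH]c1=O` likewise reaches only a limit, > 10000 nM. Compound 1 `COc1ccc([C@H](C)N(Cc2ccc(C(C)(C)C)cc2)Cc2cc3cc(OC)ccc3[nH]c2=O)cc1` gives a number, 4100 nM. The single step among these three, a step that the two limits leave unreadable from compound 2 to compound 3, cannot be sized, since the limit of > 10000 nM in this assay, at which 2 of the 3 values shown sit, covers both of its ends. Compound 4 `COc1ccc([C@H](C)N(Cc2ccc(C(C)(C)C)cc2)Cc2cc3cc(C4CC4)ccc3[nH]c2=O)cc1` is compound 3 with a different group on the amine nitrogen: 1-(4-methoxyphenyl)ethyl in place of 3-chloro-4-(trifluoromethyl)benzyl on an amine nitrogen. Among the measured compounds shown here, no measured step covers this exchange. Compound 4 carries the same amine substituent as compound 1, whose value is a number inside the range, and the same core as compound 3, which sits at the limit. Compound 4 is expected to lie between the two, an estimated 6000 nM with a range from 2500 nM to 14000 nM. That estimate means an expected step of an at least 1.6-fold lower number from compound 3 to compound 4 (0.22 log units; that floor lies within the scatter).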

Compound 4, half-maximal cytotoxic concentration: > 10000 nM
Compound 4: only a limit was reported (the forecaster's own chance of this, stated with the estimate: 40%); at least 1.6-fold (0.22 log units) between middle value and limit.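

In this assay, among the compounds shown here, cyclopropyl in place of methoxy on an aromatic carbon, with the amine nitrogen substituents unchanged, gives an at least 2.4-fold higher number from compound 1 to compound 4 (0.38 log units; beyond the scatter), so this exchange is the first that can be sized and more compound is tolerated with cyclopropyl. For compound 4, > 10000 nM is a limit. The steps among compound 2, compound 3 and compound 4 cannot be read: the limit of > 10000 nM in this assay, at which 3 of the 4 values shown sit.

On these data alone, how far the number rises with cyclopropyl remains open. Also open, as far as these compounds go, is how an ethyl group or an amine on that aromatic carbon would compare.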